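The source may report more compounds than this note shows. Statements on the series, on what has been measured and on what is new or still open speak of the compounds shown alone.

Measured in a functional assay on HCC70 cells (Homo sapiens) for antiproliferative activity, read by crystal violet staining, with a stated time of 96 h; a higher number here means that more compound is needed for the effect, a lower number that less compound is needed:
compound 1 `O[C@@H]1CO[C@@H](Oc2ccc3ccccc3c2)C[C@H]1O` gives 228 uM
compound 2 `CO[C@H]1[C@H](Oc2ccc3ccccc3c2)OC[C@@H](O)[C@@H]1O` gives 127 uM
compound 3 `CO[C@@H]1[C@@H](O)[C@H](Oc2ccc3ccccc3c2)OC[C@H]1O` gives 145 uM

One single-point change is available within the set: from compound 2 to compound 1, (hydrogen in place of methoxy on a saturated ring carbon), which produced a 1.8-fold higher number from compound 2 to compound 1 (0.25 log units; within the scatter). Compound 3 has the same atoms as compound 2, joined differently; the difference between the two cores is not broken down here, and the two values of compound 2 and compound 3 in this assay lie close to each other.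

Compound 4 `O[C@@H]1CO[C@@H](Oc2ccc3ccccc3c2)[C@H](O)C1` is not yet measured. It arises from compound 3 by hydrogen in place of methoxy on a saturated ring carbon, the same kind of change as from compound 2 to compound 1, but at a different place: here the saturated ring carbon is next to two ring atoms that each bear a hydroxy group, two ring bonds from the ring atom that bears a large group and three ring bonds from the ring oxygen, whereas in compound 2 it is next to the ring atom that bears a hydroxy group, next to the ring atom that bears a large group and two ring bonds from the ring oxygen. Among the compounds with values here, with only one earlier instance, the expectation for compound 3 to compound 4 in this assay is a step of about a 1.4-fold higher number from compound 3 to compound 4 (0.14 log units; within the scatter), resting on the earlier 1.8-fold higher number from compound 2 to compound 1 (0.25 log units; within the scatter). Compound 4 is therefore estimated at 200 uM, with a plausible range from 100 uM to 400 uM.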

Compound 4, concentration for half-maximal effect: 179 uM
For compound 4 the middle estimate is 1.1-fold (0.05 log units) above the measured one, and the stated range covers the measured number.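

The replacement of methoxy by hydrogen on a saturated ring carbon can now be compared on two cores in this assay, and the two steps do not differ: the same change on two cores in this assay, a 1.8-fold higher number (0.25 log units; within the scatter) from compound 2 to compound 1 and a 1.2-fold higher number (0.09 log units; within the scatter) from compound 3 to compound 4, 1.5-fold (0.16 log units) apart, within the scatter of two such steps. The new step, a 1.2-fold higher number from compound 3 to compound 4 (0.09 log units; within the scatter), stays within the scatter like the earlier one, and the change therefore carries across these two cores only as a step that cannot be told from no change. This does not show that methoxy has a real effect on either core, nor that a larger step would carry over in the same way.

The compounds shown leave open whether another group at these ring carbons, such as an amine or a longer alkoxy chain, would give a step beyond the scatter. Also open, as far as these compounds go, is whether the step keeps its size with a different large group, for example one bearing a carboxylic acid.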